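Amide substituent variation at the carbonyl carbon of the shared core

A few compounds are considered here, and "the series" means these few. Any claim that something is new, unique, unknown or untested is made for them only; others in the source may bear on it.

Within the data shown here, compound 2 `O=C(C1CCC(F)(F)CC1)N1CCc2nc(C#Cc3ccccc3)sc2C1` stands at the lower of the two numbers measured so far: in an assay on HEK293 cells for positive allosteric modulation of metabotropic glutamate receptor 5 (Homo sapiens), read by FLIPR, with a stated time of 1 h (a higher number here means that more compound is needed for the effect, a lower number that less compound is needed), compound 2 gives 70 nM. Among the measured compounds shown here, its nearest neighbour is compound 1 `O=C(C1CCCO1)N1CCc2nc(C#Cc3ccccc3)sc2C1`, which in this assay gives 790 nM; the only step recorded, an 11-fold lower number from compound 1 to compound 2 (1.05 log units; beyond the scatter), is large and beyond the scatter.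

Compound 3 `CC1CCC(C(=O)N2CCc3nc(C#Cc4ccccc4)sc3C2)CC1` differs from compound 2 in one place: 4-methylcyclohexyl in place of 4,4-difluorocyclohexyl on a carbonyl carbon. For the measured compounds named here, no measured pair shows this particular exchange. Going by the values given here, the single step that bears on the region, an 11-fold lower number from compound 1 to compound 2 (1.05 log units; beyond the scatter), replaces a five-membered ring holding an oxygen with a six-membered carbon ring, so it does not speak directly to swapping two fluorines for a methyl on an otherwise identical six-membered carbon ring. Both compound 2 and compound 3 keep that ring on the carbonyl carbon, which leaves the expectation close to compound 2, with a modest shift toward a higher number considered more likely than a lower one, and a step of a 1.6-fold higher number from compound 2 to compound 3 (0.20 log units; within the scatter) expected in this assay.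

Compound 3 is therefore estimated at 110 nM in this assay, with a range from 35 nM to 350 nM.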

Compound 3, half-maximal effective concentration: 190 nM
Beside the measured number, compound 3's estimate is 1.7-fold (0.24 log units) below it; the range from low to high includes it.
By their numbers in this assay, from the lowest: compound 2; then compound 3; then compound 1.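

In this assay, the exchange of 4,4-difluorocyclohexyl for 4-methylcyclohexyl on a carbonyl carbon keeps the six-membered ring of carbon only and alters what that ring carries, and it gives a 2.7-fold higher number from compound 2 to compound 3 (0.43 log units; beyond the scatter), so this position responds to the ring's substituent as well as to the ring itself. The step of a 4.2-fold lower number from compound 1 to compound 3 (0.62 log units; beyond the scatter), with 4-methylcyclohexyl in place of oxolan-2-yl, is smaller than an 11-fold lower number from compound 1 to compound 2 (1.05 log units; beyond the scatter), so the gain seen on leaving oxolan-2-yl depends on which six-membered carbon ring enters. No measurement at hand bears on why the two fluorines and the methyl differ in this way.

From the compounds shown here alone, with only these two substituted rings to compare, it remains open where an unsubstituted cyclohexyl, a 4-fluorocyclohexyl or a 4-trifluoromethylcyclohexyl would fall relative to them. Going by these compounds, it is equally open whether a 4-hydroxycyclohexyl, a phenyl ring or an open chain such as tert-butyl on the same carbonyl carbon would hold the lower numbers or lose them.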